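Swapping Cyclohexyl for 4-Fluorophenyl in Compound 3

The source may hold more compounds than are shown below. What is called first, only, known or untested is meant among the compounds shown, and "the series" means these compounds.

Of the compounds shown here, three have been measured so far in a functional assay; a higher number here means a weaker inhibitor, a lower number a stronger inhibitor. Compound 1 (`O=c1oc(-c2ccccc2)nn1CCCCN1CCN(C2CCCCC2)CC1`) gives 73.1 ug/mL, and compound 2 (`Cc1ccc(CN(C)CCCCn2nc(-c3ccccc3)oc2=O)c(C)c1`) gives 31.4 ug/mL. Compound 3 (`O=C1CCc2ccccc2N1CCCCN1CCN(C2CCCCC2)CC1`) gives 38.3 ug/mL, a value within the usual scatter of repeated measurements from each of the other two. On these numbers, compound 3 cannot be ranked against either of them.

Compound 4 (`O=C1CCc2ccccc2N1CCCCN1CCN(c2ccc(F)cc2)CC1`) has not yet been measured. It differs from compound 3 in one place: 4-fluorophenyl in place of cyclohexyl on an amine nitrogen in a ring. Within the data shown here, compound 1 carries the same cyclohexyl group as compound 3, but no measured compound carries the 4-fluorophenyl group, so the data contain no direct measure of this swap. With compound 3 at 38.3 ug/mL as the only close reference, no step beyond the scatter is expected in this assay, and neither direction can be favoured with confidence. The estimated change is a 1.1-fold lower number from compound 3 to compound 4 (0.04 log units; within the scatter). The range is kept wide because this expectation rests on so few compounds. For compound 4 the expected value is 35 ug/mL, with an estimated range of 12 ug/mL to 100 ug/mL.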

Compound 4, half-maximal inhibitory concentration: 24 ug/mL
Compound 4: middle estimate off by 1.5-fold (0.16 log units), on the high side, within the range that was stated.
By their numbers in this assay, from the lowest: compounds 4, 2, 3 and 1 (each within the scatter of the next, the first and the last beyond it).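

In this assay, the swap of cyclohexyl for 4-fluorophenyl on an amine nitrogen in a ring now has a direct reading: a 1.6-fold lower number from compound 3 to compound 4 (0.20 log units; within the scatter). At this position and on this core, then, a six-membered aromatic ring carrying fluorine and a six-membered non-aromatic ring of carbon only cannot be told apart by this measurement, so the place tolerates this change without a step beyond the scatter. No measured property is available that bears on this result, so the reading stands as a bare number with nothing to explain it.

On these data alone, whether the fluorine plays any part stays open, since a plain phenyl group or a 4-chlorophenyl group at this place would be needed to separate its contribution from that of the aromatic ring itself. Also open, as far as these compounds go, is whether the same swap gives a similar step on the core of compound 1, which carries cyclohexyl as well, and what a much smaller group such as methyl, or a pyridine ring, would do at this position.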